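Ring-amine substituent swap on the shared core

The source may hold more compounds than are shown below. What is called first, only, known or untested is meant among the compounds shown, and "the series" means these compounds.

Among the measured compounds shown here, compound 1 `Cc1nnc(N2CCC(C(=O)N3N=CC[C@H]3c3cc(F)cc(F)c3)CC2)o1` gives 1.3 L/kg in an ADME assay on the whole organism (Rattus norvegicus) for pharmacokinetics, at a dose of 1 mg/kg by the intravenous route (on this read-out lower numbers stand for narrower distribution and higher numbers for wider distribution into tissues), the lowest of the three numbers measured so far, though its steps to the other two lie within the scatter. Compound 3 `Cc1nnc(N2CCC(C(=O)N3N=CC[C@H]3c3ccccc3)CC2)o1` gives 1.6 L/kg in this assay, and compound 2 `O=C(c1cnco1)N1CCC(C(=O)N2N=CC[C@H]2c2ccccc2)CC1` gives 2.1 L/kg there. The two steps measured are a 1.2-fold higher number from compound 1 to compound 3 (0.09 log units; within the scatter) and a 1.3-fold lower number from compound 2 to compound 3 (0.12 log units; within the scatter); the second exchanges the group on the amine nitrogen in a ring, the same place that is changed below.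

Compound 4 `N#Cc1cnc(N2CCC(C(=O)N3N=CC[C@H]3c3cc(F)cc(F)c3)CC2)cn1` differs from compound 1 in one place: 5-cyanopyrazin-2-yl in place of 5-methyl-1,3,4-oxadiazol-2-yl on an amine nitrogen in a ring. For the measured compounds named here, the one exchange measured at that place, from compound 2 to compound 3, stayed within the scatter, and the exchange of phenyl in place of 3,5-difluorophenyl did likewise. The step expected in this assay is therefore no change at the digits printed from compound 1 to compound 4 (within the scatter), nothing beyond the scatter in either direction. Compound 4 is estimated at 1.3 L/kg in this assay, with a range from 0.7 L/kg to 2.5 L/kg.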

Compound 4, volume of distribution at steady state: 6.1 L/kg
The estimate for compound 4 lay 4.7-fold (0.67 log units) below the measured number; measured number outside the range, above it.
By their numbers in this assay, from the lowest: compounds 1, 3 and 2 (each within the scatter of the next); then compound 4.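

Among the compounds shown here, at the amine nitrogen in a ring, the group exchanged can move the number in this assay: 5-cyanopyrazin-2-yl in place of 5-methyl-1,3,4-oxadiazol-2-yl gives the first step beyond the scatter (a 4.7-fold higher number from compound 1 to compound 4 (0.67 log units; beyond the scatter)). For the compounds shown here, the earlier exchange at this place, on the phenyl compounds, stayed within the scatter (a 1.3-fold lower number from compound 2 to compound 3 (0.12 log units; within the scatter)), so the place does not answer alike to every exchange, although the two compounds here differ in only one group. Nothing measured on these compounds bears on the reason for the step.

Open, from the compounds shown here alone, is whether the step follows the nitrile or the six-membered aromatic ring that bears it; a pyrazin-2-yl carrying a methyl group or a carboxylic acid instead of the nitrile would separate the two. Also open, going by these compounds, is whether the step holds with phenyl in place of 3,5-difluorophenyl.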